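From 3-fluorophenyl to 4-chlorophenyl on compound 2

The source may report more compounds than this note shows. Statements on the series, on what has been measured and on what is new or still open speak of the compounds shown alone.

In a functional assay on CRL2813 cells (Homo sapiens) for cytotoxicity, read by sulforhodamine B assay, with a stated time of 5 days (a higher number here means a weaker inhibitor, a lower number a stronger inhibitor), compound 1 `O=C(Nc1cccc(C(F)(F)F)c1)N[C@H]1CC[C@H](O)CC1` gives > 20000 nM, which is a limit of the assay and not a number. Within the data shown here, compound 2 `O=C(Nc1cccc(F)c1)N[C@H]1CC[C@H](Oc2ccc(F)cc2)CC1` gives 8300 nM, the only actual number so far. Compound 3 `O=C(Nc1ccc(Cl)cc1)N[C@H]1CC[C@H](Oc2ccc(F)cc2)CC1` carries 4-chlorophenyl in place of 3-fluorophenyl on an amide-type nitrogen. Among the measured compounds shown here, no measured pair of compounds bears on this change. In this assay the estimated step of a 1.4-fold lower number from compound 2 to compound 3 (0.14 log units; within the scatter) is expected to stay within the scatter, leaning slightly towards stronger inhibition. For compound 3 the estimate is 6000 nM, with an expected range of 2500 nM to 15000 nM.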

Compound 3, half-maximal inhibitory concentration: > 20000 nM
Compound 3: a limit, no number; the forecaster's own chance of this, stated with the estimate: 7%; middle value at least 3.3-fold (0.52 log units) from the limit.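

The change from 3-fluorophenyl to 4-chlorophenyl on the amide-type nitrogen is not neutral in this assay: it gives an at least 2.4-fold higher number from compound 2 to compound 3 (0.38 log units; beyond the scatter). The group on this nitrogen can therefore separate a measurable value from none, with the 4-fluorophenyl ether part held constant. The value of compound 3 is a limit and not a number, so the step gives only a minimum size: the limit of > 20000 nM in this assay, at which 2 of the 3 values shown sit.

On these data alone, it remains open whether the step goes with the change of halogen or with its place on the ring, and a 3-chlorophenyl on this nitrogen would tell these apart. Also open, as far as these compounds go, is how an unsubstituted phenyl would behave here.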